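Replacing the pyrazole arm of compound 2 with a methylcarbamoyl group

This account rests on a few compounds, and the source may have more. Where it says the series, first, only, none or still open, it means among the compounds named here.

Compound 1 `CC(C)Oc1cc(-c2cncc(-c3cnn(C4COC4)c3)c2)ccc1C(N)=O` and compound 2 `CC(C)Oc1cc(-c2cncc(-c3cnn(C)c3)c2)ccc1C(N)=O` share a core and differ only at the nitrogen of the pyrazole ring. In an assay on cells for inhibition of MAP kinase-interacting serine/threonine-protein kinase 2 (Homo sapiens), read by mobility shift assay, with stated times of 10 min and 60 min, in the presence of a further agent that is not named here (on this read-out higher numbers stand for weaker inhibition and lower numbers for stronger inhibition), compound 1 gives 89 nM, and compound 2 gives 160 nM. The change of methyl in place of oxetan-3-yl on an aromatic nitrogen produced a 1.8-fold higher number from compound 1 to compound 2 (0.25 log units; within the scatter), so the two numbers cannot be told apart. Within the data shown here, compound 2 holds the higher of the two numbers, with compound 1 as its only neighbour.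

Compound 3 `CNC(=O)c1cncc(-c2ccc(C(N)=O)c(OC(C)C)c2)c1` departs from compound 2 by a larger change: methylcarbamoyl in place of 1-methyl-1H-pyrazol-4-yl on an aromatic carbon. Among the measured compounds shown here, no measured step concerns this position, since the single step from compound 1 to compound 2 touched only the substituent on the pyrazole nitrogen and stayed within the scatter. The removal of a whole aromatic ring in favour of a small amide is therefore unguided by the data, and a loss of inhibition beyond the scatter is expected, corresponding to a 6.3-fold higher number from compound 2 to compound 3 (0.80 log units; beyond the scatter). On that basis compound 3 is expected to give about 1000 nM in this assay, with a plausible range from 200 nM to 5000 nM.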

Compound 3, half-maximal inhibitory concentration: 630 nM
Beside the measured number, compound 3's estimate is 1.6-fold (0.20 log units) above it; measured number inside the range.
By their numbers in this assay, from the lowest: compounds 1 and 2 (each within the scatter of the next); then compound 3.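

The earlier step touched only the substituent on the pyrazole nitrogen, whereas this one exchanges the whole arm on an aromatic carbon, two atoms from the ring nitrogen. In this assay, replacing 1-methyl-1H-pyrazol-4-yl with methylcarbamoyl gives a 3.9-fold higher number from compound 2 to compound 3 (0.60 log units; beyond the scatter), and replacing 1-(oxetan-3-yl)-1H-pyrazol-4-yl with the same group gives a 7.1-fold higher number from compound 1 to compound 3 (0.85 log units; beyond the scatter), so this position responds to a change of the whole arm beyond the scatter, unlike the change on the pyrazole nitrogen. Even so, the five-membered aromatic ring is not needed for measurable inhibition, as compound 3 still gives 630 nM, although nothing shown explains the loss.

Because ring and amide change in a single step, the compounds shown cannot separate the loss of the ring from the arrival of the methylcarbamoyl group. As far as these compounds go, it also remains open how an amine, a carboxylic acid or a longer chain on the amide nitrogen would read at this position, and whether any such group could come back to the level of the pyrazole-bearing compounds.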